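A Chloro Group Added to an Analogue Without Measurable Activity

A few compounds are considered here, and "the series" means these few. Any claim that something is new, unique, unknown or untested is made for them only; others in the source may bear on it.

Compound 1 `Cc1ccc(C)c(-n2nncc2CN2C(=O)C3(C(C#N)=C(N)Oc4c3c3nc5ccccc5nc3c3ccccc43)c3ccccc32)c1` and compound 2 `Cc1ccc(-n2nncc2CN2C(=O)C3(C(C#N)=C(N)Oc4c3c3nc5ccccc5nc3c3ccccc43)c3ccccc32)c(C)c1` differ only in the dimethylphenyl group on an aromatic nitrogen. In a functional assay on MCF7 cells (Homo sapiens) for antiproliferative activity, read by MTT assay, with a stated time of 48 h (on this read-out lower numbers stand for stronger inhibition and higher numbers for weaker inhibition), compound 1 gives > 50000 nM, which is a limit of the assay rather than a number. Compound 2 likewise gives > 50000 nM, again a limit. The step that the two limits leave unreadable from compound 1 to compound 2 is therefore unreadable. Compound 3 `N#CC1=C(N)Oc2c(N)cc3nc4ccccc4nc3c2C12C(=O)N(Cc1cnnn1-c1ccc(F)cc1)c1ccccc12` gives > 50000 nM in this assay, also a limit. Compound 3 thus sits at the limit of > 50000 nM in this assay, at which 3 of the 3 values shown sit, where every measured value rests. Compound 4 `N#CC1=C(N)Oc2c(N)cc3nc4ccccc4nc3c2C12C(=O)N(Cc1cnnn1-c1ccc(F)c(Cl)c1)c1ccccc12` differs from compound 3 by chloro in place of hydrogen on an aromatic carbon. Going by the values given here, no measured step bears on this change, so the expected step that the limit leaves unreadable from compound 3 to compound 4 has no readable direction beyond the scatter. Compound 4 is expected to give 60000 nM, between 15000 nM and 250000 nM, most probably again only a limit.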

Compound 4, half-maximal inhibitory concentration: 17800 nM
Compound 4: the middle estimate sits 3.4-fold (0.53 log units) above what was measured; the measured number falls inside the stated range.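

In this assay, 3-chloro-4-fluorophenyl in place of 4-fluorophenyl gives an at least 2.8-fold lower number from compound 3 to compound 4 (0.44 log units; beyond the scatter). The value of compound 3 is a limit, not a number. This is the first change shown that brings a value off that limit, so a single chloro on this aromatic carbon, ortho to the fluoro group, is enough to give a readable number: the limit of > 50000 nM in this assay, at which 3 of the 4 values shown sit.

As far as these compounds go, whether chloro is special here stays open, as a bromo or methyl group on the same carbon could give a higher or lower number. From the compounds shown here alone, it is also open whether chloro would have this effect without the fluoro group.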